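Acetylated nucleoside amides: chain extension and microsomal half-life

This account rests on a few compounds, and the source may have more. Where it says the series, first, only, none or still open, it means among the compounds named here.

Compound 1 `CC(=O)NC/C=C\CN(C)C[C@H]1O[C@@H](n2cnc3c(N)ncnc32)[C@H](O)[C@@H]1O` and compound 2 `CCC(=O)NC/C=C\CN(C)C[C@H]1O[C@@H](n2cnc3c(N)ncnc32)[C@H](O)[C@@H]1O` share a core and differ by methyl in place of hydrogen on a saturated chain carbon bound to a carbonyl carbon. In an ADME assay on microsomes from liver (Mus musculus) for metabolic stability, read by LC-MS, using NADPH, tested at 1 uM (on this read-out higher numbers stand for a longer-lived compound and lower numbers for a shorter-lived compound), compound 1 gives > 1.5 h, which is a limit of the assay and not a number. In this assay compound 2 gives > 1.5 h, likewise a limit. The step that the two limits leave unreadable from compound 1 to compound 2 cannot be read, because both values sit at the limit of > 1.5 h in this assay, at which 2 of the 3 values shown sit. Among the compounds with values here, compound 3 `CCC(=O)NC/C=C\CN(C)C[C@H]1O[C@@H](n2cnc3c(N)ncnc32)[C@H](OC(C)=O)[C@@H]1OC(C)=O` carries a core whose difference from that of compound 1 is not broken down here; in this assay compound 3 gives 0.0767 h, the only number in the set. Compound 4 `CCCC(=O)NC/C=C\CN(C)C[C@H]1O[C@@H](n2cnc3c(N)ncnc32)[C@H](OC(C)=O)[C@@H]1OC(C)=O` differs from compound 3 by methyl in place of hydrogen on a saturated chain carbon, two bonds along the chain from a carbonyl carbon. This is the same kind of change as that from compound 1 to compound 2, but the place differs: on a saturated chain carbon bound to a carbonyl carbon there, two bonds along the chain from a carbonyl carbon here. With the measured pair unreadable, the step is expected to be small, a 1.1-fold lower number from compound 3 to compound 4 (0.04 log units; within the scatter). Compound 4 is estimated at 0.07 h, between 0.03 h and 0.16 h.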

Compound 4, half-life: 0.05 h
Compound 4: middle estimate off by 1.4-fold (0.15 log units), on the high side; measured number inside the range.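

On the core of compound 3, methyl in place of hydrogen on a saturated chain carbon, two bonds along the chain from a carbonyl carbon, gives in this assay a 1.5-fold lower number from compound 3 to compound 4 (0.19 log units; within the scatter). This single pair shows a step inside the scatter on that core, but it does not show that the change carries from one core to another. The pair compound 1 and compound 2 carries the methyl at a different place on the chain and cannot be read, because both of its values are limits: the limit of > 1.5 h in this assay, at which 2 of the 4 values shown sit.

On these data alone, it remains open how the half-life would respond to a longer chain on either core. The same question stands for an amine or a carboxylic acid on that chain.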